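Halogen swaps on the shared core: toward compound 4

The source may hold more compounds than are shown below. What is called first, only, known or untested is meant among the compounds shown, and "the series" means these compounds.

Measured in a functional assay on the whole organism with Mus musculus as the target, in the writhing test; a lower number here means that less compound is needed, a higher number that more compound is needed for the effect:
compound 1 `Cc1[nH]c2ccc(Cl)cc2c1SC1CCNCC1` — compound 1 gives 0.8 mg/kg
compound 2 `Cc1[nH]c2ccc(Br)cc2c1SC1CCNCC1` — compound 2 gives 0.7 mg/kg
compound 3 `Cc1[nH]c2ccc(F)cc2c1SC1CCNCC1` — compound 3 gives 5.9 mg/kg

Compound 3 stands highest of the three numbers in this assay: its nearest neighbour is compound 1, with a 7.4-fold higher number from compound 1 to compound 3 (0.87 log units; beyond the scatter), and the furthest is compound 2, with an 8.4-fold higher number from compound 2 to compound 3 (0.93 log units; beyond the scatter). Between compound 1 and compound 2 there is a 1.1-fold lower number from compound 1 to compound 2 (0.06 log units; within the scatter).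

Compound 4 `Cc1[nH]c2ccc(C(F)(F)F)cc2c1SC1CCNCC1` differs from compound 3 by trifluoromethyl in place of fluoro on an aromatic carbon. For the measured compounds named here, no measured step introduces a trifluoromethyl group, so the only guide is the same position: moving from fluoro to chloro or to bromo there gave the steps above, both beyond the scatter and both toward a lower number. On that basis a lower number is expected for compound 4 in this assay, roughly a 3.9-fold lower number from compound 3 to compound 4 (0.59 log units; beyond the scatter), with the width of the range reflecting the absence of a directly comparable step. The estimate for compound 4 is 1.5 mg/kg, expected between 0.5 mg/kg and 5 mg/kg.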

Compound 4, dose for half-maximal effect: 19.4 mg/kg
Compound 4: the middle estimate sits 13-fold (1.11 log units) below what was measured; measured number above the stated range.
By their numbers in this assay, from the lowest: compounds 2 and 1 (each within the scatter of the next); then compound 3; then compound 4.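

In this assay replacing fluoro at this place does not always lower the number: trifluoromethyl gives a 3.3-fold higher number from compound 3 to compound 4 (0.52 log units; beyond the scatter) and so runs opposite to the chloro and bromo steps from the same compound. The gap to those two halogens is wide, with a 24-fold higher number from compound 1 to compound 4 (1.38 log units; beyond the scatter) and a 28-fold higher number from compound 2 to compound 4 (1.44 log units; beyond the scatter) and both exceed every step among compounds 1, 2 and 3. The series therefore does not follow a single trend across the four groups at this place, and no measurement at hand accounts for the order.

Still open, going by these compounds, is whether the higher number is specific to trifluoromethyl or is shared by other groups at this place, such as methyl, methoxy or nitrile. Iodo would show whether the flat chloro and bromo result extends further along the halogens.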